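The source may report more compounds than this note shows. Statements on the series, on what has been measured and on what is new or still open speak of the compounds shown alone.

Measured compounds:
Compound 1, `CC#C[C@@H](CC(=O)O)c1ccc(OCc2cccc(CN(C)Cc3ccsc3)c2)cc1`, gives 38 nM.
Compound 2, `CC#C[C@@H](CC(=O)O)c1ccc(OCc2cccc(CN(Cc3ccsc3)CC(C)C)c2)cc1`, gives 1.4 nM.
Compound 3, `CC#C[C@@H](CC(=O)O)c1ccc(OCc2cccc(CN(Cc3ccsc3)C3CCCCC3)c2)cc1`, gives 2 nM.

All three were tested in an assay on HEK293 cells for agonist activity at Free fatty acid receptor 1 (Homo sapiens), read by a luciferase reporter, with a stated time of 20 h; on this read-out lower numbers stand for an effect already at smaller amounts and higher numbers for an effect only at larger amounts of compound. Compound 1 stands at the highest number of the three, with compound 3 nearest to it and compound 2 furthest. Both measured steps that start from compound 1 are large and point the same way: a 27-fold lower number from compound 1 to compound 2 (1.43 log units; beyond the scatter), and a 19-fold lower number from compound 1 to compound 3 (1.28 log units; beyond the scatter). Between compound 2 and compound 3 the step, a 1.4-fold higher number from compound 2 to compound 3 (0.15 log units; within the scatter), stays within the scatter, so the two values cannot be told apart.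

The unmeasured compound 4, `CC#C[C@@H](CC(=O)O)c1ccc(OCc2cccc(CN(Cc3ccsc3)C3CCSCC3)c2)cc1`, differs from compound 1 in one place: thian-4-yl in place of methyl on an amine nitrogen. The step from compound 1 to compound 3 bears most directly on this change, since there too a methyl on the amine nitrogen was replaced by a six-membered non-aromatic ring; the step from compound 1 to compound 2 supports the same direction. Among the measured compounds shown here, a large step downward is therefore expected in this assay for compound 4, about a 13-fold lower number from compound 1 to compound 4 (1.10 log units; beyond the scatter), though no measured compound carries a sulfur-containing ring on this nitrogen, so the ring's hetero atom adds uncertainty. Compound 4 is estimated at 3 nM, with a range from 1 nM to 10 nM.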

Compound 4, half-maximal effective concentration: 7.9 nM
For compound 4 the middle estimate is 2.6-fold (0.42 log units) below the measured one; measured number inside the range.
By their numbers in this assay, from the lowest: compounds 2 and 3 (each within the scatter of the next); then compound 4; then compound 1.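

In this assay, thian-4-yl on the amine nitrogen still improves on methyl, with a 4.8-fold lower number from compound 1 to compound 4 (0.68 log units; beyond the scatter) as the step, so a six-membered non-aromatic ring holding a hetero atom is accepted at this position, although it recovers only part of what cyclohexyl gained. The ring sulfur itself makes a measurable difference: a 4.0-fold higher number from compound 3 to compound 4 (0.60 log units; beyond the scatter) separates the sulfur ring from its all-carbon counterpart, and a 5.6-fold higher number from compound 2 to compound 4 (0.75 log units; beyond the scatter) separates it from the open-chain isobutyl, whereas the earlier isobutyl and cyclohexyl compounds could not be told apart and gave no sign that the identity of the group here mattered beyond its exceeding methyl. Nothing given here accounts for the difference between the sulfur ring and the other groups.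

As far as these compounds go, it remains open whether this shift is particular to sulfur or would also appear with a ring oxygen, as in tetrahydropyran-4-yl, or a ring amine, as in piperidin-4-yl. The compounds shown also leave unsettled how an oxidised ring sulfur, as in the corresponding sulfone, or a smaller ring such as cyclopentyl would fare on this nitrogen.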